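Cytotoxicity of an alkoxy-purine series: predicting compound 4

The source may hold more compounds than are shown below. What is called first, only, known or untested is meant among the compounds shown, and "the series" means these compounds.

Three compounds sharing one core have been examined in an ADME assay on MOLT-3 cells (Homo sapiens) for cytotoxicity, with a stated time of 7 days; on this read-out lower numbers stand for higher toxicity in this test and higher numbers for lower toxicity in this test. Compound 1 `CC(C)CNc1nc(N)nc2c1ncn2/C=C1/CC1(CO)CO` gives "not determined" (no result reported) in this assay. Compound 2 `CCCOc1nc(N)nc2c1ncn2/C=C1/CC1(CO)CO` gives > 20000 nM in this assay, which is a limit and not a number. Compound 3 `Nc1nc(OCc2ccccc2)c2ncn(/C=C3/CC3(CO)CO)c2n1` gives > 20000 nM in this assay, again a limit and not a number. The step from compound 2 to compound 3, a step that the two limits leave unreadable from compound 2 to compound 3, therefore cannot be sized, since both ends sit at the limit of > 20000 nM in this assay, at which 2 of the 3 values shown sit.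

Compound 4 `CCCCCCOc1nc(N)nc2c1ncn2/C=C1/CC1(CO)CO` has not yet been measured. It differs from compound 3 by pentyl in place of phenyl on a saturated chain carbon bound to an oxygen on an aromatic ring. Within the data shown here, the only measured step bears on this change without giving a size, so no change beyond the scatter can be read from it. Two of the three compounds rest at the same limit, and compound 4 is expected to do the same, with an estimated step that the limit leaves unreadable from compound 3 to compound 4. Compound 4 is thus estimated at 30000 nM in this assay, within a range from 12000 nM to 100000 nM.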

Compound 4, half-maximal cytotoxic concentration: > 20000 nM
Compound 4: no number, only a limit; the forecaster's own chance of this, stated with the estimate: 85%; the middle value lies beyond the limit too.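

In this assay, among these compounds, compound 2, compound 3 and compound 4 each give only a limit and not a number, so no step among them can be read: the limit of > 20000 nM in this assay, at which 3 of the 4 values shown sit. The compounds shown leave open how far each true value lies past that limit, and whether propyloxy, benzyloxy and hexyloxy differ at all.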